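Chloro for hydrogen on the benzoyl group of compound 3

This account rests on a few compounds, and the source may have more. Where it says the series, first, only, none or still open, it means among the compounds named here.

Measured so far:
Compound 1 `CN1CCN(c2ccc(Nc3nc(-c4cccc(NC(=O)c5ccc(F)cc5)c4)sc3C(N)=O)cc2)CC1`: in a functional assay on Ramos cells (Homo sapiens) for antiproliferative activity, read by CCK-8 assay, with a stated time of 72 h (on this read-out higher numbers stand for weaker inhibition and lower numbers for stronger inhibition), compound 1 gives 1420 nM.
Compound 2 `CN1CCN(c2ccc(Nc3nc(-c4cccc(NC(=O)c5ccc(C(C)(C)C)cc5)c4)sc3C(N)=O)cc2)CC1`: in this assay compound 2 gives 8600 nM.
Compound 3 `CN1CCN(c2ccc(Nc3nc(-c4cccc(NC(=O)c5ccccc5)c4)sc3C(N)=O)cc2)CC1`: in this assay compound 3 gives 1760 nM.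

Compound 3 holds the second highest number of the three in this assay. Its nearest neighbour is compound 1, and the step of a 1.2-fold higher number from compound 1 to compound 3 (0.09 log units; within the scatter) is within the scatter, so no order between these two is claimed. Compound 2 stands furthest away, a 4.9-fold lower number from compound 2 to compound 3 (0.69 log units; beyond the scatter).

Compound 4 `CN1CCN(c2ccc(Nc3nc(-c4cccc(NC(=O)c5ccc(Cl)cc5)c4)sc3C(N)=O)cc2)CC1` differs from compound 3 by chloro in place of hydrogen on an aromatic carbon. Within the data shown here, two measured steps bear on this position. Fluoro against hydrogen, a 1.2-fold higher number from compound 1 to compound 3 (0.09 log units; within the scatter), makes no difference beyond the scatter. Tert-butyl raises the number in both comparisons, a 6.1-fold higher number from compound 1 to compound 2 (0.78 log units; beyond the scatter) and a 4.9-fold lower number from compound 2 to compound 3 (0.69 log units; beyond the scatter). Chloro enters as one heavy atom, so in what it adds it sits nearer to fluoro and hydrogen than to tert-butyl. The expected step of a 1.1-fold higher number from compound 3 to compound 4 (0.06 log units; within the scatter) is therefore small, at most modestly toward a higher number, and may well fall within the scatter. Compound 4 is estimated at 2000 nM, with a range from 900 nM to 5000 nM.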

Compound 4, half-maximal inhibitory concentration: 1360 nM
The estimate for compound 4 lay 1.5-fold (0.17 log units) above the measured number, within the range that was stated.
By their numbers in this assay, from the lowest: compounds 4, 1 and 3 (each within the scatter of the next); then compound 2.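

In this assay, the change from phenyl to 4-chlorophenyl gives a step within the scatter (a 1.3-fold lower number from compound 3 to compound 4 (0.11 log units; within the scatter)), and chloro against fluoro is also within the scatter (a 1.0-fold lower number from compound 1 to compound 4 (0.02 log units; within the scatter)), so no order is read among hydrogen, fluoro and chloro at this place. Against tert-butyl, chloro gives a step beyond the scatter (a 6.3-fold lower number from compound 2 to compound 4 (0.80 log units; beyond the scatter)), which leaves compound 2 as the only one of the four compounds set apart from the others, with compounds 1, 3 and 4 forming one group within the scatter. Nothing on hand gives a reason for these steps or explains why tert-butyl alone stands apart.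

The compounds shown leave open whether any group at this place gives a number beyond the scatter on the lower side of compounds 1, 3 and 4, for example an amine, a carboxylic acid, a methoxy group or a longer chain. They also leave open whether chloro keeps this behaviour on another carbon of the same ring, or when the shared core is changed elsewhere.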